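This account rests on a few compounds, and the source may have more. Where it says the series, first, only, none or still open, it means among the compounds named here.

Of the compounds shown here, three have so far been measured in an ADME assay on MT2 cells (Homo sapiens) for cytotoxicity, read by MTT assay; a higher number here means that more compound is tolerated, a lower number that less compound is tolerated.
Compound 1 `N#Cc1ccc2c(Oc3ccc(F)cc3OCCn3ccc(=O)[nH]c3=O)cc(Cl)cc2c1` gives 16000 nM.
Compound 2 `N#Cc1cc2c(Oc3ccccc3OCCn3ccc(=O)[nH]c3=O)cc(Cl)cc2o1` gives only a limit of the assay, > 100000 nM.
Compound 3 `N#Cc1ccc2c(Oc3ccc(F)cc3OCCn3ccc(=O)[nH]c3=O)cccc2c1` gives only a limit of the assay, > 100000 nM.

Compound 1 and compound 3 share one core and differ in a single place: hydrogen in place of chloro on an aromatic carbon. That change brought an at least 6.2-fold higher number from compound 1 to compound 3 (0.79 log units; beyond the scatter), so more of compound 3 than of compound 1 is tolerated by the cells. Compound 2 is built on a different core from compound 1; the difference between the two cores is not broken down here. The same kind of change, made on compound 2, leads to compound 4 `N#Cc1cc2c(Oc3ccccc3OCCn3ccc(=O)[nH]c3=O)cccc2o1`, which has not yet been measured: hydrogen in place of chloro on an aromatic carbon. The two places read the same word for word.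

In this assay the step from compound 2 to compound 4 is expected to be small in number but to keep the compound at the top of the range, because compound 2 already sits at the limit of > 100000 nM in this assay, at which 2 of the 3 values shown sit, and the same change gave an at least 6.2-fold higher number from compound 1 to compound 3 (0.79 log units; beyond the scatter). Compound 4 is therefore expected to give about 150000 nM, most likely reported again only as a limit, within roughly 80000 nM to 400000 nM. This estimate means a step that the limit leaves unreadable from compound 2 to compound 4.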

Compound 4, half-maximal cytotoxic concentration: > 100000 nM
Compound 4 was reported as a limit (the forecaster's own chance of this, stated with the estimate: 85%); the middle value is on the limit's open side.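

In this assay the change from chloro to hydrogen between compound 2 and compound 4 cannot be read as a step, because both compounds give only the same limit: the limit of > 100000 nM in this assay, at which 3 of the 4 values shown sit. The compounds shown leave open whether this change shifts the number at all on the core of compound 2, as it does between compound 1 and compound 3.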